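Adding a longer amine chain to compound 1

The source may hold more compounds than are shown below. What is called first, only, known or untested is meant among the compounds shown, and "the series" means these compounds.

Within the data shown here, in an ADME assay on microsomes from liver (Mus musculus) for metabolic stability, using NADPH, with a stated time of 10 min (a higher number here means that more of the compound is left, a lower number that less of the compound is left), compound 1 (`CN(C[C@H]1Cc2ncccc2CN1)[C@H]1CCCc2cccnc21`) gives 53%, the highest of the three numbers so far. Two relatives carry 3-aminoprop-1-en-1-yl in place of hydrogen on a saturated chain carbon bound to an amine nitrogen. Of these, compound 2 (`NC/C=C\CN(C[C@H]1Cc2ncccc2CN1)[C@H]1CCCc2cccnc21`) gives 37%, and compound 3 (`NC/C=C/CN(C[C@H]1Cc2ncccc2CN1)[C@H]1CCCc2cccnc21`) gives 37%. Adding that chain therefore produced a number 16 percentage points lower from compound 1 to compound 2 (beyond the scatter), and also a number 16 percentage points lower from compound 1 to compound 3 (beyond the scatter). The two chain-bearing compounds form a close pair, given (the fact that compounds 2 and 3 differ only in the configuration as drawn), and this assay shows no change at the digits printed from compound 2 to compound 3 (within the scatter).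

Compound 4 (`CCN(CC)CCCCN(C[C@H]1Cc2ncccc2CN1)[C@H]1CCCc2cccnc21`) has not yet been measured. Its structure differs as follows: 3-(diethylamino)propyl in place of hydrogen on a saturated chain carbon bound to an amine nitrogen. Among the measured compounds shown here, this 3-(diethylamino)propyl group enters at the same kind of place as the chain in compounds 2 and 3, so those are the steps that bear on it. For the measured compounds named here, with only this pair as a guide, and with a number 16 percentage points lower from compound 1 to compound 2 (beyond the scatter) as the closest precedent, a modest fall is expected again, perhaps somewhat larger given the longer chain. The expected change is a number 23 percentage points lower from compound 1 to compound 4 (beyond the scatter). The estimate for compound 4 is 30%, within an expected range of 12% to 50%.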

Compound 4, percent of the compound remaining: 1%
Compound 4: middle estimate off by 29 percentage points, on the high side; measured number below the stated range.
By their numbers in this assay, from the lowest: compound 4; then compounds 2 and 3 (each within the scatter of the next); then compound 1.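

Placing 3-(diethylamino)propyl on a saturated chain carbon bound to an amine nitrogen gives a number 52 percentage points lower from compound 1 to compound 4 (beyond the scatter) in this assay, so the size of the fall at this position depends on which chain enters, something the matching values of compounds 2 and 3 could not show. The chains also differ clearly from each other, as 3-(diethylamino)propyl in place of 3-aminoprop-1-en-1-yl gives a number 36 percentage points lower from compound 3 to compound 4 (beyond the scatter), and the same exchange gives a number 36 percentage points lower from compound 2 to compound 4 (beyond the scatter). These two steps are of equal size and start from a close pair, so they amount to much the same comparison seen twice: the fact that compounds 2 and 3 differ only in the configuration as drawn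

Compound 4 differs from compounds 2 and 3 in the diethylamino end, the saturated chain and the chain length all at once, so the compounds shown do not tell which of these goes with the larger fall. A plain 4-aminobutyl chain, which keeps the saturated chain but has an unsubstituted amine at its end, would begin to separate these features, while a chain ending in a carboxylic acid would test whether an amine at the end matters at all.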